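Secondary amine in place of diethylamino on the shared core

The source may report more compounds than this note shows. Statements on the series, on what has been measured and on what is new or still open speak of the compounds shown alone.

Compound 1 `CCN(CC)Cc1ccc(Cl)c(-c2ccccc2OC)c1` carries a diethylamino group and is recorded in a functional assay on HEK293 cells for agonist activity at 5-hydroxytryptamine receptor 7 (Homo sapiens), read by a luciferase reporter and beta-arrestin recruitment, with a stated time of 22 h (on this read-out lower numbers stand for smaller maximal responses and higher numbers for larger maximal responses), as "not active" (no number reported), so no number stands for it. Compound 2 `CNCc1ccc(Cl)c(-c2ccccc2OC)c1`, with a methylamino group in the same position, gives 61% in this assay, and compound 3 `COc1ccccc1-c1cc(C2CCNC2)ccc1Cl` gives 54%; the step of a number 7 percentage points lower from compound 2 to compound 3 (within the scatter) shows that two different secondary amines here give similar responses. Compound 4 `CCCNCc1ccc(Cl)c(-c2ccccc2OC)c1` differs from compound 1 by propylamino in place of diethylamino on a saturated chain carbon bound to an aromatic carbon. Going by the values given here, no measured step matches this change, but the two secondary amines compound 2 and compound 3 both give measurable responses. Compound 4 is therefore expected to give a measurable response, estimated at 55%, with a plausible range from 30% to 75%.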

Compound 4, largest response reached (Emax), in percent of the reference or control that the assay uses: "not active" (no number reported)
No number was reported for compound 4; there is nothing to compare the estimate with.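

Compound 1 and compound 4 both stand without a number, so no step can be read between them. The compounds shown leave open why compound 4 differs from compound 2, and no measurement here bears on that.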